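The source may report more compounds than this note shows. Statements on the series, on what has been measured and on what is new or still open speak of the compounds shown alone.

Measured compounds:
compound 1 `Cc1ccccc1Oc1ccc(N2C[C@@H](C(F)(F)F)C[C@H]2CC(=O)O)cc1` with 35 nM
compound 2 `O=C(O)C[C@@H]1CCCN1c1ccc(OCc2ccc(Cl)cc2Cl)cn1` with "not determined" (no result reported)

Among the compounds with values here, compound 1 is the only compound with a number in an assay on HEK293 cells for binding affinity to Free fatty acid receptor 1 (Homo sapiens), read by scintillation counting and radioligand binding, with a stated time of 1 h (a higher number here means a weaker inhibitor, a lower number a stronger inhibitor), so it stands alone; compound 2 offers nothing to compare. Compound 3 `Cc1ccccc1Oc1ccc(N2CCC[C@H]2CC(=O)O)cc1` is not yet measured. It differs from compound 1 as follows: hydrogen in place of trifluoromethyl on a saturated ring carbon. Within the data shown here, no measured pair shows what this change does, so the expectation rests on compound 1 and the change alone. The step from compound 1 to compound 3 is expected to be a modest weakening, about a 2.9-fold higher number from compound 1 to compound 3 (0.46 log units; beyond the scatter), likely beyond the usual scatter. Compound 3 is therefore estimated at 100 nM, within a range from 30 nM to 400 nM.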

Compound 3, inhibition constant: 4400 nM
The estimate for compound 3 lay 44-fold (1.64 log units) below the measured number; measured number above the stated range.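

In this assay, hydrogen in place of trifluoromethyl on this saturated ring carbon gives a 130-fold higher number from compound 1 to compound 3 (2.10 log units; beyond the scatter) and shows that binding strength depends heavily on what this one ring position carries. The step is large for a change at a single place, and the rest of the molecule stays the same. Nothing shown here explains the size of this loss. As far as these compounds go, whether a methyl group or a single fluorine atom on this carbon would recover the value of compound 1 remains open, so it is unclear what trifluoromethyl itself contributes.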